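The source may report more compounds than this note shows. Statements on the series, on what has been measured and on what is new or still open speak of the compounds shown alone.

For the measured compounds named here, compound 2 `CC(=O)N[C@H]1[C@@H](OC[C@@H](O)[C@@H](O)[C@H](O)[C@@H](O)CNc2cccc(NC(=O)CCCCC3CCSS3)c2)O[C@H](COS(=O)(=O)O)[C@H](O)[C@@H]1O[C@@H]1O[C@H](C(=O)O)[C@@H](O)[C@H](O)[C@H]1O` holds the only number reported in an assay on isolated protein for binding affinity to fibroblast growth factor 2 (Homo sapiens), read by surface plasmon resonance; a higher number here means weaker binding, a lower number tighter binding: in this assay compound 2 gives 36 nM. Going by the values given here, compound 1 `CC(=O)N[C@H]1[C@@H](OC[C@@H](O)[C@@H](O)[C@H](O)[C@@H](O)CNc2cccc(NC(=O)CCCCC3CCSS3)c2)O[C@H](CO)[C@H](OS(=O)(=O)O)[C@@H]1O[C@@H]1O[C@H](C(=O)O)[C@@H](O)[C@H](O)[C@H]1O` was reported in this assay only as "not active" (no number reported), without any number, so no step between two measured compounds can be sized here. Compound 3 `CC(=O)N[C@H]1[C@@H](OC[C@@H](O)[C@@H](O)[C@H](O)[C@@H](O)CNc2cccc(NC(=O)CCCCC3CCSS3)c2)O[C@H](COS(=O)(=O)O)[C@H](OS(=O)(=O)O)[C@@H]1O[C@@H]1O[C@H](C(=O)O)[C@@H](O)[C@H](O)[C@H]1O` differs from compound 2 by sulfo in place of hydrogen on an oxygen on a saturated carbon. Nothing measured tells how such an added sulfo group shifts binding in this series, so the expectation rests on compound 2 alone and on the small size of the change. Among the compounds with values here, with no measured step to lean on, the expected step is a 1.8-fold lower number from compound 2 to compound 3 (0.26 log units; within the scatter), modest, leaning toward tighter binding and possibly no larger than the scatter. Compound 3 is therefore expected to give about 20 nM in this assay, with a likely range from 6 nM to 70 nM.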

Compound 3, dissociation constant: 16 nM
For compound 3 the middle estimate is 1.3-fold (0.10 log units) above the measured one, within the range that was stated.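

For the compounds shown here, replacing hydroxy with sulfooxy at this oxygen gives the first step that can be sized: a 2.3-fold lower number from compound 2 to compound 3 (0.35 log units; beyond the scatter) in this assay, a modest gain in binding that lies beyond the usual scatter. The added group does not bring this binding by itself, since compound 1 carries it but lacks the other sulfooxy group of compound 3, and compound 1 is reported as "not active" (no number reported). Nothing measured here explains the shift.

This single pair cannot show whether the gain depends specifically on sulfooxy at this oxygen. From the compounds shown here alone, a phosphate, a carboxylic acid or a methyl ether in the same place could give a similar, larger or smaller shift, so how binding here responds to other groups remains open.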